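The source may hold more compounds than are shown below. What is called first, only, known or untested is meant among the compounds shown, and "the series" means these compounds.

Compound 1, `O=C(Nc1cccc(S(=O)(=O)C2CCCC2)n1)c1ccc(NCCO)cc1N1CCC2(CC1)CC2`, stands second highest of the three numbers in a functional assay on OVCAR-3 cells (Homo sapiens) for activation, with a stated time of 24 h (on this read-out higher numbers stand for an effect only at larger amounts of compound and lower numbers for an effect already at smaller amounts), where compound 1 gives 177 nM. The nearest value belongs to compound 3, `CC(C)(C)NS(=O)(=O)c1cccc(NC(=O)c2ccc(NC(C)(C)CO)nc2N2CCC3(CC2)CC3)n1`, which in this assay gives 43 nM, and the furthest to compound 2, `CC(C)(CO)S(=O)(=O)c1cccc(NC(=O)c2cccnc2N2CCC3(CC2)CC3)c1`, which gives 45900 nM. The unmeasured compound 4, `COc1ccc(C(=O)Nc2cccc(S(=O)(=O)C3CCCC3)n2)c(N2CCC3(CC2)CC3)c1`, differs from compound 1 in one place: methoxy in place of (2-hydroxyethyl)amino on an aromatic carbon. Among the compounds with values here, no step between two measured compounds that differ in one place is available, so the size of this step must be guessed. The account expects a moderate loss for compound 4, a step of a 2.8-fold higher number from compound 1 to compound 4 (0.45 log units; beyond the scatter) toward higher numbers, beyond the scatter. Compound 4 is accordingly estimated at 500 nM, within a range from 120 nM to 2500 nM.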

Compound 4, half-maximal effective concentration: 2660 nM
For compound 4 the middle estimate is 5.3-fold (0.73 log units) below the measured one; the whole stated range lies below it.
By their numbers in this assay, from the lowest: compound 3; then compound 1; then compound 4; then compound 2.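

In this assay, putting methoxy in place of (2-hydroxyethyl)amino on this aromatic carbon gives a 15-fold higher number from compound 1 to compound 4 (1.18 log units; beyond the scatter) and so shows that a single change at this position, para to a large group, can move the number by a large step. The change also removes all hydrogen-bond donors of the group that leaves, but it alters several counts at once and these cannot be separated here. Nothing measured here accounts for the size of this step. The compounds shown leave open whether a plain amine or a longer hydroxyalkyl chain at this position would match compound 1 or fall nearer compound 4 .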